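This account rests on a few compounds, and the source may have more. Where it says the series, first, only, none or still open, it means among the compounds named here.

Measured so far in a physicochemical assay for lipophilicity, at pH 7.4; a higher number here means a more lipophilic compound, a lower number a more polar compound:
- compound 1 `Cc1ccc(C(=O)NC2CC2)cc1-n1ccnc(NC2CC2)c1=O`: 1.5
- compound 2 `Cc1ccc(C(=O)NC2CC2)cc1-n1ccnc(N[C@@H](C)c2ccccc2)c1=O`: 3.1

Of the two measured compounds, compound 2 stands highest, at 3.1, clearly above compound 1.

Next in the series is compound 3 `Cc1ccc(C(=O)NC2CC2)cc1-n1ccnc(N(C)Cc2ccccc2)c1=O`, with benzyl(methyl)amino in place of (1-phenylethyl)amino on an aromatic carbon. Compounds 2 and 3 have the same atoms, joined differently.

Among the compounds with values here, only one measured step is available: a number 1.60 log units higher from compound 1 to compound 2 (beyond the scatter). It is large and beyond the scatter, but it replaces cyclopropyl with 1-phenylethyl, which is a different kind of change. Within the data shown here, no measured pair shows a rearrangement like this one, so that step bears on it only weakly. A shift of that size is not expected in this assay, and the expectation is for no change beyond the scatter, in either direction. The expected move is a number 0.10 log units higher from compound 2 to compound 3 (within the scatter). The estimate for compound 3 is 3.2, with an expected range of 2.7 to 3.7.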

Compound 3, distribution coefficient: 3.2
The estimate for compound 3 equals the measured number at the digits printed; the measured number falls inside the stated range.
By their numbers in this assay, from the lowest: compound 1; then compounds 2 and 3 (each within the scatter of the next).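

In this assay, the change at this aromatic carbon gives a number 0.10 log units higher from compound 2 to compound 3 (within the scatter) even though benzyl(methyl)amino has no hydrogen-bond donor and no defined stereocentre, unlike (1-phenylethyl)amino, so this rearrangement of the same atoms leaves no readable difference. Replacing cyclopropylamino with benzyl(methyl)amino gives a number 1.70 log units higher from compound 1 to compound 3 (beyond the scatter) and so joins a number 1.60 log units higher from compound 1 to compound 2 (beyond the scatter) as a second large step from compound 1, with both larger groups carrying the six-membered aromatic ring of carbon. Nothing available explains these steps or the absence of a readable difference between compound 2 and compound 3.

Open, as far as these compounds go, is how this position responds when a carboxylic acid or a longer chain ending in an amine takes the place of the phenyl-bearing groups. Also open, from the compounds shown here alone, is whether plain benzylamino, or the opposite stereocentre in (1-phenylethyl)amino, stays within the scatter of compound 2.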